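The compounds below may be only part of what the source reports. "The series", "measured", "known", "first", "only" and "open" are said of these compounds alone.

Measured compounds:
compound 1 `CC1(Cc2ccccc2)CC(S(=O)(=O)c2cccc(F)c2)=C(c2ccc(/C(N)=N\O)cc2)O1` with 28300 nM
compound 2 `CC1(c2ccc(-c3ccc(/C(N)=N\O)cc3)cc2)CC(S(=O)(=O)c2ccc(F)cc2)=C(c2ccc(/C(N)=N\O)cc2)O1` with 3940 nM

Of the compounds shown here, two have been tested in an ADME assay on J774.A1 cells (Mus musculus) for cytotoxicity, read by MTT assay, with a stated time of 72 h; on this read-out higher numbers stand for lower toxicity in this test and lower numbers for higher toxicity in this test. Compound 1 `CC1(Cc2ccccc2)CC(S(=O)(=O)c2cccc(F)c2)=C(c2ccc(/C(N)=N\O)cc2)O1` gives 28300 nM in this assay, and compound 2 `CC1(c2ccc(-c3ccc(/C(N)=N\O)cc3)cc2)CC(S(=O)(=O)c2ccc(F)cc2)=C(c2ccc(/C(N)=N\O)cc2)O1` gives 3940 nM. Of these two numbers, compound 2 stands at the lower one, and the gap to compound 1 lies beyond the scatter of the test.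

Compound 3 `CC1(c2ccc(-c3ccccc3C#N)cc2)CC(S(=O)(=O)c2ccc(F)cc2)=C(c2ccc(/C(N)=N\O)cc2)O1` has not yet been measured. It differs from compound 2 in one place: a group of 8 heavy atoms (7 carbon, 1 nitrogen; one six-membered aromatic ring of carbon only) in place of a group of 10 heavy atoms (7 carbon, 2 nitrogen, 1 oxygen; one six-membered aromatic ring of carbon only), on an aromatic carbon.

Among the compounds with values here, no measured pair shows this change, so its size cannot be read from the data. The author expects only a small step, a 1.6-fold higher number from compound 2 to compound 3 (0.22 log units; within the scatter), probably within the scatter, perhaps tilted toward a higher number. For compound 3 the estimate in this assay is 6500 nM, with a range from 2000 nM to 22000 nM.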

Compound 3, half-maximal cytotoxic concentration: 9290 nM
Compound 3: middle estimate off by 1.4-fold (0.16 log units), on the low side; measured number inside the range.
By their numbers in this assay, from the lowest: compound 2; then compound 3; then compound 1.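

Within the data shown here, at this position, on an aromatic carbon para to a large group, the earlier compounds offered no change in one place, and compound 3 now supplies one. In this assay, 2-cyanophenyl entering in place of the group of 10 heavy atoms gives a 2.4-fold higher number from compound 2 to compound 3 (0.37 log units; beyond the scatter), a modest move towards lower toxicity in this test, so the position tolerates a group with 0 hydrogen-bond donors in place of one with 2 without a rise in toxicity. No measurement shown here explains the step.

As far as these compounds go, it remains open whether the nitrile itself matters or whether a plain phenyl group would give a similar number. Equally open, from the compounds shown here alone, is how a carboxylic acid or an amine on this ring would read in this assay.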